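Replacing the acetylphenyl arm of compound 1 with a chlorine atom

This account rests on a few compounds, and the source may have more. Where it says the series, first, only, none or still open, it means among the compounds named here.

Compound 1, with the structure `CC(=O)c1cccc(-c2sc(N)c(C(=O)c3ccccc3)c2-c2cccc(C(F)(F)F)c2)c1`, was tested in a functional assay on CHO-K1 cells for agonist activity at adenosine receptor A1 (Homo sapiens), read by GTPgammaS binding; a lower number here means that less compound is needed, a higher number that more compound is needed for the effect. In this assay compound 1 gives only a limit, > 10 uM, and not a number. Its close relative compound 2, `CCOC(=O)c1c(N)sc(-c2cccc(C(C)=O)c2)c1-c1cccc(C(F)(F)F)c1`, carries an ethoxy in place of a phenyl on a carbonyl carbon; in this assay compound 2 likewise gives only the limit > 10 uM. The step that the two limits leave unreadable from compound 1 to compound 2 therefore cannot be read, since (the limit of > 10 uM in this assay, at which 2 of the 2 values shown sit).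

Compound 3, with the structure `Nc1sc(Cl)c(-c2cccc(C(F)(F)F)c2)c1C(=O)c1ccccc1`, has not yet been measured in this assay. It differs from compound 1 by chloro in place of 3-acetylphenyl on an aromatic carbon; in words, a chloro replaces the 3-acetylphenyl on an aromatic carbon of the shared core, next to the ring sulfur. Among the measured compounds shown here, the one measured step concerns a different position, the carbonyl substituent, and gives no readable size, so it says nothing about how much a change at this ring carbon may move the value.

Compound 3 is therefore expected to stay near the limit, with an estimated value of 15 uM and a range from 3 uM to 60 uM, which would mean a step that the limit leaves unreadable from compound 1 to compound 3.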

Compound 3, concentration for half-maximal effect: > 10 uM
Compound 3: no number, only a limit; the forecaster's own chance of this, stated with the estimate: 70%; the middle value lies beyond the limit too.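

No new step can be read between compound 1 and compound 3, since in this assay each gives only a limit and not a number: the limit of > 10 uM in this assay, at which 3 of the 3 values shown sit. The compounds shown leave open what actual values lie behind that limit, and whether chloro in place of 3-acetylphenyl on an aromatic carbon changes the value at all.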